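This account rests on a few compounds, and the source may have more. Where it says the series, first, only, none or still open, it means among the compounds named here.

Measured compounds:
compound 1, `Nc1nn(C(=O)Nc2ccc(Cc3ccccc3)cc2)c2ccccc12` — > 100000 nM
compound 2, `Nc1nn(C(=O)Nc2ccc(Cc3ccccc3)cc2)c2ccc(Cl)cc12` — > 100000 nM

In a functional assay on COLO 205 cells (Homo sapiens) for antiproliferative activity, read by sulforhodamine B assay, with a stated time of 48 h (a lower number here means that less compound is tolerated, a higher number that more compound is tolerated), compound 1 gives > 100000 nM, which is a limit of the assay rather than a number. Compound 2 gives > 100000 nM in this assay, again a limit. The step from compound 1 to compound 2, a step that the two limits leave unreadable from compound 1 to compound 2, cannot be read in size because of the limit of > 100000 nM in this assay, at which 2 of the 2 values shown sit. Compound 2 therefore stands at the limit of this assay, with no number of its own; all that is known is that both measured compounds are tolerated up to that limit.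

Compound 3, `Nc1ccc2c(c1)c(N)nn2C(=O)Nc1ccc(Cc2ccccc2)cc1`, differs from compound 2 in one place: amino in place of chloro on an aromatic carbon. Within the data shown here, no measured step touches this exchange of chloro for amino, and the single step known, from compound 1 to compound 2, is itself unreadable. The expectation for compound 3 rests only on the fact that compound 2 sits at the limit of this assay. The step from compound 2 to compound 3 is therefore estimated as a number no higher from compound 2 to compound 3 (the limit leaves the size open), nothing beyond the scatter. Compound 3 is expected to give about 100000 nM in this assay, within a range of 30000 nM to 300000 nM, most likely reported again as a limit.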

Compound 3, concentration lethal to 50% of the cells: 53900 nM
Estimate against measurement, compound 3: 1.9-fold (0.27 log units) above, and the stated range covers the measured number.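

In this assay, among these compounds, compound 3 is the first of the three compounds to carry a number rather than a limit, so this aromatic carbon now has a substituent whose read-out falls within the range the assay can report. Amino in place of chloro gives an at least 1.8-fold lower number from compound 2 to compound 3 (0.26 log units; that floor lies within the scatter), and amino in place of hydrogen gives an at least 1.8-fold lower number from compound 1 to compound 3 (0.26 log units; that floor lies within the scatter). Both figures are floors rather than sizes and both lie within the scatter, so they show only that amino at this place gives a number, whereas compound 1 and compound 2, with hydrogen and chloro there, stay at the limit: the limit of > 100000 nM in this assay, at which 2 of the 3 values shown sit.

On these data alone, the true size of both steps stays open, as neither compound 1 nor compound 2 has a number of its own to set against that of compound 3. The compounds shown do not tell how a hydroxyl, a methoxy or an acetamido group on this carbon would read in this assay, or whether amino on another carbon of this ring would also give a number.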